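This account rests on a few compounds, and the source may have more. Where it says the series, first, only, none or still open, it means among the compounds named here.

Measured so far:
- compound 1, `O=C(Nc1nc(-c2ccccc2)nc2cn(-c3ccccc3)nc12)c1ccco1`: 11%
- compound 2, `O=C(c1ccco1)N(C(=O)c1ccco1)c1nc(-c2ccccc2)nc2cn(-c3ccccc3)nc12`: 3%
- compound 3, `Cc1nc(NC(=O)Nc2ccccc2)c2nn(-c3ccccc3)cc2n1`: 1%

Compound 1 holds the highest of the three numbers in an assay on CHO cells for displacement of a labelled ligand from adenosine receptor A1 (Homo sapiens), read by scintillation counting, with a stated time of 120 min, tested at 1 uM (a higher number here means more inhibition at the concentration tested (going by the name of the read-out), a lower number less inhibition), yet this says little about order: compound 2 lies nearest, lower by an amount within the scatter, and compound 3 lies furthest, also lower by an amount within the scatter. None of the three numbers can be set above or below another beyond the scatter on these readings.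

The step under consideration goes from compound 1 to compound 4, `O=C(Nc1nc(-c2ccccc2)nc2cn(-c3ccccc3)nc12)c1ccncc1`. The change is pyridin-4-yl in place of furan-2-yl on a carbonyl carbon.

Among the measured compounds shown here, only one measured step is available, a number 8 percentage points lower from compound 1 to compound 2 (within the scatter), and it concerns a different place: a (furan-2-yl)carbonyl entering on the amide-type nitrogen, not an exchange of the ring on the carbonyl carbon. For the measured compounds named here, compound 3 shares no single-point step with compound 1. Going by the values given here, no measured step therefore bears directly on the exchange of furan-2-yl for pyridin-4-yl, and the only step that exists stays within the scatter.

On this basis compound 4 is expected to show a step of a number 2 percentage points lower from compound 1 to compound 4 (within the scatter), that is, nothing beyond the scatter. The estimate for compound 4 in this assay is 9%, with a range from 0% to 25%.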

Compound 4, a percentage reported as inhibition, at one concentration (the size of the read-out at that concentration, not a potency): 1%
Estimate against measurement, compound 4: 8 percentage points above, and the stated range covers the measured number.
By their numbers in this assay, from the lowest: compounds 3, 4, 2 and 1 (each within the scatter of the next).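

In this assay, among the compounds shown here, the exchange of furan-2-yl for pyridin-4-yl on a carbonyl carbon gives a number 10 percentage points lower from compound 1 to compound 4 (within the scatter), and this is the first measured step at this place in the molecule, as the earlier step concerned the amide-type nitrogen. A five-membered aromatic ring with one hetero atom can thus give way to a six-membered aromatic ring with one hetero atom on this carbonyl carbon without separating compound 4 from compound 1 beyond the usual spread of such readings. Nothing measured here accounts for this reading, and no explanation of it can be offered.

The compounds shown leave open whether any group on this carbonyl carbon would stand apart from furan-2-yl beyond the scatter, for instance a saturated amine such as piperidin-4-yl, a carboxylic acid, or a longer chain such as butyl. They also leave open how furan-2-yl and pyridin-4-yl would compare at a concentration other than the single one reported.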